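Notes on the step from compound 3 to compound 4

A few compounds are considered here, and "the series" means these few. Any claim that something is new, unique, unknown or untested is made for them only; others in the source may bear on it.

Three compounds of the shared core have numbers in a functional assay on MCF7 cells (Homo sapiens) for antiproliferative activity, read by MTT assay, with a stated time of 48 h, tested at 25 uM; on this read-out lower numbers stand for a stronger effect and higher numbers for a weaker effect at the one concentration tested. Compound 1 `OC(CCn1nc2c(Br)c(Br)c(Br)c(Br)c2n1)c1ccccc1` gives 105%. Compound 2 `OC(CCn1nc2c(Br)c(Br)c(Br)c(Br)c2n1)c1cccc(Cl)c1` gives 101%. Compound 3 `CC(O)CCn1nc2c(Br)c(Br)c(Br)c(Br)c2n1` gives 73%, the lowest of the three numbers; its nearest neighbour is compound 2 and its furthest is compound 1, both gaps lying beyond the scatter. Compound 4 `OC(CCn1nc2c(Br)c(Br)c(Br)c(Br)c2n1)c1cccc(Br)c1` is not yet measured. It differs from compound 3 by 3-bromophenyl in place of methyl on a saturated chain carbon bound to an oxygen on a saturated carbon and a saturated chain carbon. Among the measured compounds shown here, two measured steps bear on this change when read in reverse: a number 32 percentage points lower from compound 1 to compound 3 (beyond the scatter) and a number 28 percentage points lower from compound 2 to compound 3 (beyond the scatter), both beyond the scatter, so the exchange of methyl for phenyl or for 3-chlorophenyl at this place has twice moved the number by a sizeable amount. The halogen on the aromatic ring has so far mattered little, since a number 4 percentage points lower from compound 1 to compound 2 (within the scatter). The expectation for compound 4 in this assay is therefore a rise of about a number 27 percentage points higher from compound 3 to compound 4 (beyond the scatter), beyond the scatter, back toward the numbers of compound 1 and compound 2. Compound 4 is estimated at 100%, with a range from 85% to 115%.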

Compound 4, a percentage reported as activity, at one concentration (the size of the read-out at that concentration, not a potency): 106%
For compound 4 the middle estimate is 6 percentage points below the measured one, within the range that was stated.
By their numbers in this assay, from the lowest: compound 3; then compounds 2, 1 and 4 (each within the scatter of the next).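

In this assay the change at the saturated chain carbon bound to the oxygen now holds for a third aromatic group, with 3-bromophenyl in place of methyl giving a number 33 percentage points higher from compound 3 to compound 4 (beyond the scatter) and matching the two earlier exchanges in direction. Bromo on the aromatic carbon does not separate compound 4 from its analogues, as shown by a number 5 percentage points higher from compound 2 to compound 4 (within the scatter) and by a number 1 percentage points higher from compound 1 to compound 4 (within the scatter), so hydrogen, chloro and bromo are not told apart by this read-out. Among the four compounds, only compound 3, with its methyl, stands apart from the others.

From the compounds shown here alone, whether a saturated ring such as cyclohexyl or a longer chain such as butyl would keep the number of compound 3 or that of the aromatic compounds remains open. Nothing available explains the gap between methyl and the aromatic groups.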